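Swapping the Sulfonyl Aryl Group of a Guanidine Series

This account rests on a few compounds, and the source may have more. Where it says the series, first, only, none or still open, it means among the compounds named here.

Of the compounds shown here, three have so far been measured in a functional assay on A549 cells (Homo sapiens) for antiproliferative activity, read by MTT assay, with a stated time of 72 h; a higher number here means a weaker inhibitor, a lower number a stronger inhibitor. Compound 1 `N=C(NS(=O)(=O)c1ccccc1Cl)N1CCN(c2cc3c(cc2F)c(=O)c(C(=O)O)cn3C2CC2)CC1` gives 71 nM. Compound 2 `CCn1cc(C(=O)O)c(=O)c2cc(F)c(N3CCN(C(=N)NS(=O)(=O)c4ccccc4C(F)(F)F)CC3)cc21` gives 71 nM. Compound 3 `N=C(NS(=O)(=O)c1ccccc1C(F)(F)F)N1CCN(c2cc3c(cc2F)c(=O)c(C(=O)O)cn3C2CC2)CC1` gives 71 nM. Neither single change tried so far moved the read-out: trifluoromethyl in place of chloro on an aromatic carbon gave no change at the digits printed from compound 1 to compound 3 (within the scatter), and cyclopropyl in place of ethyl on an aromatic nitrogen gave no change at the digits printed from compound 2 to compound 3 (within the scatter). Compound 2 therefore stands level with compounds 1 and 3 at the digits shown, within the scatter of both.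

Compound 4 `CCn1cc(C(=O)O)c(=O)c2cc(F)c(N3CCN(C(=N)NS(=O)(=O)c4cccc(Cl)c4)CC3)cc21` has not yet been measured in this assay . It differs from compound 2 in one place: 3-chlorophenyl in place of 2-(trifluoromethyl)phenyl on a sulfonyl sulfur. The measured step that bears on this is the exchange of chloro and trifluoromethyl on the aryl group attached to the sulfonyl sulfur, which gave no change at the digits printed from compound 1 to compound 3 (within the scatter). For the measured compounds named here, no measured pair tests the 3-chlorophenyl arrangement itself, so that part of the change is untested. Because no change at the digits printed from compound 1 to compound 3 (within the scatter) showed nothing beyond the scatter, the step from compound 2 to compound 4 is expected to be small, no change at the digits printed from compound 2 to compound 4 (within the scatter), in no clear direction. Compound 4 is accordingly estimated at 71 nM, with a range from 35 nM to 150 nM.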

Compound 4, half-maximal inhibitory concentration: 71 nM
Compound 4: the middle estimate sits on the measured number at the digits printed, within the range that was stated.
By their numbers in this assay, from the lowest: compounds 1, 2, 3 and 4 (each within the scatter of the next).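

In this assay, the step of no change at the digits printed from compound 2 to compound 4 (within the scatter) shows that the sulfonyl sulfur can carry 3-chlorophenyl as well as 2-(trifluoromethyl)phenyl without a read-out change beyond the scatter, even though the number in the group's name changes and the group entering has fewer heavy atoms. The earlier step on this aryl group exchanged chloro and trifluoromethyl with cyclopropyl on the aromatic nitrogen, whereas this one was taken with ethyl there, so an aryl change at the sulfonyl sulfur has now been seen to leave the read-out within the scatter with each of these two nitrogen groups. No accompanying evidence accounts for this flat result, and the numbers alone give no explanation for it.

The compounds shown leave open whether any group on the sulfonyl sulfur can shift the read-out beyond the scatter, since all the aryl groups here carry a single chloro or trifluoromethyl group. An aryl group bearing an amine or a carboxylic acid, or a plain methyl or longer alkyl chain in place of the aryl ring, would test how far this flat behaviour extends.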